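Chloro in Place of Hydroxymethyl on the Aryl Ether

The source may hold more compounds than are shown below. What is called first, only, known or untested is meant among the compounds shown, and "the series" means these compounds.

The series shares one core, seen in compound 1 `CNC[C@]1(O)Cc2ccccc2[C@@H]1Oc1ccccc1F`, compound 2 `CNC[C@]1(O)Cc2ccccc2[C@@H]1Oc1ccccc1CO` and compound 3 `CNC[C@]1(O)Cc2ccccc2[C@@H]1Oc1cc(F)ccc1C`, and differs only in the substituents on the aryl ether. In an in vitro ADME assay on microsomes from liver (Rattus norvegicus) for metabolic stability (a lower number here means slower removal, a higher number faster removal of the compound), compound 1 reports a limit of the assay rather than a number, <= 3 mL/min/kg. Compound 3 gives 7 mL/min/kg in this assay. Compound 2 stands apart: in this assay it is recorded as "not determined" (no result reported), so no number places it among the others. The evidence available in this set is the limit of <= 3 mL/min/kg in this assay, at which 1 of the 3 values shown sits.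

Compound 4 `CNC[C@]1(O)Cc2ccccc2[C@@H]1Oc1ccccc1Cl` is the next member, not yet measured in this assay. It differs from compound 2 as follows: chloro in place of hydroxymethyl on an aromatic carbon. With no number for compound 2, the size of the step cannot be judged from the data; the other two members suggest clearance at the low end of the scale, and compound 4 is expected to stay there, any difference from compound 3 lying within the usual scatter. Compound 4 is estimated to give 4 mL/min/kg in this assay, with a range from 2 mL/min/kg to 9 mL/min/kg.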

Compound 4, clearance: 10 mL/min/kg
Compound 4: middle estimate off by 2.5-fold (0.40 log units), on the low side, outside the stated range (above it).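

In this assay, chloro in place of fluoro on this aromatic carbon, ortho to a large group, gives an at least 3.3-fold higher number from compound 1 to compound 4 (0.52 log units; beyond the scatter), so the position is not indifferent to which halogen it carries. Compound 1 reports <= 3 mL/min/kg, which is a limit of the assay and not a number. The reading of this change therefore rests on one compound at that limit, and the data give no cause for the rise: the limit of <= 3 mL/min/kg in this assay, at which 1 of the 4 values shown sits.

On these data alone, the step from compound 2 to compound 4 cannot be read, so how hydroxymethyl compares with either halogen at this place remains unknown. Nor do the compounds shown tell where a bromo, a methoxy, a nitrile or an amine on this same carbon would fall in this assay.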